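The source may report more compounds than this note shows. Statements on the series, on what has been measured and on what is new or still open speak of the compounds shown alone.

In a functional assay on U-373MG ATCC cells (Homo sapiens) for inhibition, read by colorimetric assay and MTT assay, with a stated time of 72 h (on this read-out lower numbers stand for stronger inhibition and higher numbers for weaker inhibition), compound 1 `Cc1ccc2c(c1)-c1cnc(n1C)OCCCCCCCCO2` gives 57000 nM and compound 2 `COc1ccc2c(c1)-c1cnc(n1C)OCCCCCCCCO2` gives 63000 nM as its reading. Compound 3 `CCCCOc1ncc(-c2ccccc2OC)n1C` has no place on these numbers: compound 3 is entered as "not determined" (no result reported) in this read-out, so no single figure stands for it. The change to compound 4 `C=CCCOc1ncc(-c2ccccc2OC)n1C` is vinyl in place of ethyl on a saturated chain carbon, two bonds along the chain from an oxygen on an aromatic ring, which also reads as butoxy to (but-3-en-1-yl)oxy.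

Within the data shown here, the only measured step (a 1.1-fold higher number from compound 1 to compound 2 (0.04 log units; within the scatter)) is methoxy in place of methyl on an aromatic carbon, a different change at a different place. It gives no direct size for ethyl to vinyl, and without a number for compound 3 no step can be read at this position. From this single example, no shift beyond the scatter is expected in this assay, and no direction is favoured. Among the measured compounds shown here, the estimate therefore leans on compound 1 at 57000 nM and compound 2 at 63000 nM as the only numbers. The range stays wide, as neither is a one-place neighbour of compound 4. The estimated value for compound 4 is 60000 nM with an expected range from 20000 nM to 150000 nM in this read-out.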

Compound 4, half-maximal inhibitory concentration: 16000 nM
The estimate for compound 4 lay 3.8-fold (0.57 log units) above the measured number, outside the stated range (below it).
By their numbers in this assay, from the lowest: compound 4; then compounds 1 and 2 (each within the scatter of the next).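

No new step can be read: in this assay compound 3 has no single figure, so the change from ethyl to vinyl leading to compound 4 has no size. The compounds shown leave open whether the reading of compound 4 at 16000 nM is tied to the (but-3-en-1-yl)oxy group. No evidence bears on this result.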